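Extending an Aromatic Substituent: What to Expect for Compound 3

A few compounds are considered here, and "the series" means these few. Any claim that something is new, unique, unknown or untested is made for them only; others in the source may bear on it.

Compound 2 `O=C(NCc1ccc(CNS(=O)(=O)c2ccc(F)cc2)cc1)c1ccc(F)cc1` is measured in an assay on MDA-MB-231 cells for binding affinity to C-X-C chemokine receptor type 4 (Homo sapiens), read by fluorescence and microscopy, with stated times of 10 min and 30 min (a higher number here means that more compound is needed for the effect, a lower number that less compound is needed), at 1 nM, level with compound 1 `CCN(CC)Cc1ccc(S(=O)(=O)NCc2ccc(CNC(=O)c3ccc(F)cc3)cc2)cc1`, which gives 1 nM. Compound 3 `O=C(NCc1ccc(CNS(=O)(=O)c2ccc(-c3ccc(F)cc3)cc2)cc1)c1ccc(F)cc1` carries 4-fluorophenyl in place of fluoro on an aromatic carbon. Within the data shown here, only one measured step concerns that same aromatic carbon: no change at the digits printed from compound 1 to compound 2 (within the scatter), where swapping one group for another left the value unchanged. That step offers no direct guide to a larger group entering there, so only a small step is expected in this assay, with some room for a weaker result. Compound 3 is estimated at 2 nM, within 0.5 nM to 10 nM, which means an expected step of a 2.0-fold higher number from compound 2 to compound 3 (0.30 log units; within the scatter).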

Compound 3, effective concentration (reported as EC, without a stated level of effect): 100 nM
Estimate against measurement, compound 3: 50-fold (1.70 log units) below, and the stated range ends below it.
By their numbers in this assay, from the lowest: compounds 1 and 2 (each within the scatter of the next); then compound 3.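

In this assay this aromatic carbon proves far from indifferent to what it carries: 4-fluorophenyl in place of fluoro gives a 100-fold higher number from compound 2 to compound 3 (2.00 log units; beyond the scatter), and in place of (diethylamino)methyl it gives a 100-fold higher number from compound 1 to compound 3 (2.00 log units; beyond the scatter). Among these compounds, the agreement between fluoro and (diethylamino)methyl therefore does not extend to every group here, and the one group that puts a further aromatic ring on this carbon is the one with the much higher number. Nothing measured here gives a reason for this jump. The compounds shown leave open how a plain phenyl, a methoxy group or a carboxylic acid on this carbon would compare.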